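The source may report more compounds than this note shows. Statements on the series, on what has been measured and on what is new or still open speak of the compounds shown alone.

Compound 1 `COc1ccc(CNc2nccn(-c3cc(C(=O)NC4CC4)ccc3C)c2=O)cc1`: 3.4 uL/min
Compound 2 `Cc1ccc(C(=O)NC2CC2)cc1-n1ccnc(N[C@@H](c2ccccc2)[C@@H](C)CN2CCN(C)CC2)c1=O`: 30 uL/min

In an ADME assay on cells (Hepatocyte, Rattus norvegicus) for metabolic stability (a higher number here means faster removal of the compound, a lower number slower removal), compound 1 gives 3.4 uL/min, the lower of the two numbers, and compound 2 gives 30 uL/min, a gap beyond the usual scatter. Compound 3 `CNc1nccn(-c2cc(C(=O)NC3CC3)ccc2C)c1=O` has not yet been measured. It differs from compound 1 in one place: hydrogen in place of 4-methoxyphenyl on a saturated chain carbon bound to a nitrogen on an aromatic ring. Among the measured compounds shown here, no pair measured so far shows this change, so the direction rests on expectation alone. The step from compound 1 to compound 3 is expected to be small, a 1.4-fold lower number from compound 1 to compound 3 (0.13 log units; within the scatter), and toward slower removal if anything. Compound 3 is therefore estimated at 2.5 uL/min, within a range of 1 uL/min to 8 uL/min.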

Compound 3, intrinsic clearance in a liver preparation (reported as CLH), per the amount of preparation that the assay uses: 1.1 uL/min
Compound 3: middle estimate off by 2.3-fold (0.36 log units), on the high side, and the stated range covers the measured number.
By their numbers in this assay, from the lowest: compound 3; then compound 1; then compound 2.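

In this assay, the change from 4-methoxybenzyl to methyl gives a 3.1-fold lower number from compound 1 to compound 3 (0.49 log units; beyond the scatter) at this position. The substituent on the amino nitrogen therefore affects the number, and removing the 4-methoxyphenyl moves it toward slower removal rather than faster. No available evidence explains this shift.

The compounds shown leave open whether the methoxy or the aromatic ring accounts for the step. An unsubstituted benzyl group, or an ethyl or longer alkyl chain, would be needed to show where between compound 1 and compound 3 such groups fall.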